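This account rests on a few compounds, and the source may have more. Where it says the series, first, only, none or still open, it means among the compounds named here.

Working notes on the series. Compound 2 `O=C1NC(c2ccccc2)CN1S(=O)(=O)c1ccc(Cl)cc1` gives 1430 nM in a functional assay on SK-MEL-2 cells (Homo sapiens) for cytotoxicity; on this read-out higher numbers stand for weaker inhibition and lower numbers for stronger inhibition. Compound 1 `Cc1ccc(S(=O)(=O)N2CC(c3ccccc3)NC2=O)cc1` gives 2530 nM in this assay; the change methyl in place of chloro on an aromatic carbon produced a 1.8-fold higher number from compound 2 to compound 1 (0.25 log units; within the scatter). Compound 3 `Cc1ccc(C2CNC(=O)N2S(=O)(=O)c2ccc(Cl)cc2)cc1` gives 255000 nM in this assay, the highest of the three numbers; the difference between the core of compound 3 and the core of compound 2 is not broken down here. Compound 4 `Cc1ccc(C2CNC(=O)N2S(=O)(=O)c2ccc(C)cc2)cc1` is not yet measured in this assay. For the measured compounds named here, it differs from compound 3 by methyl in place of chloro on an aromatic carbon, the same change, at the same place, as the one from compound 2 to compound 1. A step of about the same size is expected, a 1.4-fold higher number from compound 3 to compound 4 (0.14 log units; within the scatter). That expectation rests on compound 2 and compound 1 alone, where a 1.8-fold higher number from compound 2 to compound 1 (0.25 log units; within the scatter) stayed within the scatter, so a single prior example only. For compound 4 the estimate in this assay is 350000 nM, with a range from 120000 nM to 1000000 nM.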

Compound 4, half-maximal inhibitory concentration: 234000 nM
For compound 4 the middle estimate is 1.5-fold (0.17 log units) above the measured one; low and high end bracket the measured number.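

In this assay methyl in place of chloro gives a 1.1-fold lower number from compound 3 to compound 4 (0.04 log units; within the scatter) and so stays within the scatter on this core as well. Set side by side, the two steps show no difference between the cores: the same change on two cores in this assay, a 1.8-fold higher number (0.25 log units; within the scatter) from compound 2 to compound 1 and a 1.1-fold lower number (0.04 log units; within the scatter) from compound 3 to compound 4, 1.9-fold (0.29 log units) apart, within the scatter of two such steps. This shows that the change made no readable difference on either of these two cores, but two pairs do not show that it would stay this small on any further core, and they do not tell what the change would do where the number is otherwise different.

The compounds shown compare only 4-chlorophenyl and 4-methylphenyl at this place. Going by these compounds, whether a methoxy group, an amine or a carboxylic acid there would move the number on either core remains open.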